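A Methylphenyl Swap on an Unreadable Pair

A few compounds are considered here, and "the series" means these few. Any claim that something is new, unique, unknown or untested is made for them only; others in the source may bear on it.

In a functional assay on HT29-AK cells (Homo sapiens) for cytotoxicity, read by MTT assay, with a stated time of 48 h (a lower number here means a stronger inhibitor, a higher number a weaker inhibitor), compound 1 (`Fc1cccc(-c2nc(Nc3ccc(Br)cc3)c3cc(F)ccc3n2)c1`) gives > 50000 nM as a limit of the assay, not a number. Compound 2 (`Nc1cccc(Nc2nc(-c3cccc(F)c3)nc3ccc(F)cc23)c1`) gives > 50000 nM as a limit too. Compound 2 therefore has no number of its own (the limit of > 50000 nM in this assay, at which 2 of the 2 values shown sit).

The next compound changes one group. Compound 3 (`Cc1ccc(Nc2nc(-c3cccc(F)c3)nc3ccc(F)cc23)cc1`) carries 4-methylphenyl in place of 3-aminophenyl on a nitrogen on an aromatic ring.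

Among the measured compounds shown here, only one measured step bears on this change. It is a step that the two limits leave unreadable from compound 1 to compound 2 and so offers no size to carry forward. That step swapped the group at the same place, and both compounds ended at the same limit (the limit of > 50000 nM in this assay, at which 2 of the 2 values shown sit). A step of known size or direction in this assay therefore cannot be expected, and another reading at the limit is a likely outcome for compound 3. Any number that does appear is expected to lie near that limit.

Compound 3 is estimated at 50000 nM with an expected range from 15000 nM to 100000 nM in this test. The estimated step is a number no higher from compound 2 to compound 3 (the limit leaves the size open) and it remains only an expectation.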

Compound 3, half-maximal inhibitory concentration: > 50000 nM
Compound 3: no number, only a limit; the forecaster's own chance of this, stated with the estimate: 65%; the middle value sits exactly at the limit.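

Among the compounds shown here, compound 3 also gives only a limit in this assay, not a number, so no step among compound 1, compound 2 and compound 3 can be read: the limit of > 50000 nM in this assay, at which 3 of the 3 values shown sit. The compounds shown leave open how strong each of the three is, and whether 4-bromophenyl, 3-aminophenyl or 4-methylphenyl on the nitrogen makes any difference in this assay.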